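Benzyl for Butyl on a Shared Core: Growth Inhibition Expected

The source may hold more compounds than are shown below. What is called first, only, known or untested is meant among the compounds shown, and "the series" means these compounds.

The study covers a small set of compounds built on a shared core and tested in a functional assay on G-361 cells (Homo sapiens) for cytotoxicity, read by sulforhodamine B assay; on this read-out lower numbers stand for stronger inhibition of growth and higher numbers for weaker inhibition of growth. In this assay compound 1 `CCCNc1ncnc2c1cnn2-c1ccccc1` gives > 100000 nM, which is a limit of the assay and not a number. In this assay compound 2 `CCCCNc1nc(C)nc2c1cnn2-c1ccccc1` likewise gives > 100000 nM, again a limit and not a number. Compound 2 therefore stands at the edge of what this assay can report, and the account of where it stands is summed up in the observation (the limit of > 100000 nM in this assay, at which 2 of the 2 values shown sit).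

Compound 3 `Cc1nc(NCc2ccccc2)c2cnn(-c3ccccc3)c2n1` has not yet been measured. It differs from compound 2 in one place: phenyl in place of propyl on a saturated chain carbon bound to a nitrogen on an aromatic ring. Among the measured compounds shown here, since both values shown sit at the limit, no measured step can guide the size of this change. Compound 3 is expected to remain at or near that limit, so the step of a number no higher from compound 2 to compound 3 (the limit leaves the size open) is expected to be none beyond the scatter. Compound 3 is estimated at 100000 nM, within a range from 20000 nM to 300000 nM.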

Compound 3, concentration for total growth inhibition: > 100000 nM
Compound 3: only a limit was reported (the forecaster's own chance of this, stated with the estimate: 70%); the middle value sits exactly at the limit.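

In this assay compound 3 gives > 100000 nM, a limit and not a number. Compound 2 sits at the same limit, so no step between compound 2 and compound 3 can be read: the limit of > 100000 nM in this assay, at which 3 of the 3 values shown sit.

The compounds shown leave open whether any change on the shared core brings growth inhibition within what this assay can report as a number.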